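A few compounds are considered here, and "the series" means these few. Any claim that something is new, unique, unknown or untested is made for them only; others in the source may bear on it.

Working notes on the series in a functional assay on PC-3 cells (Homo sapiens) for inhibition, read by MTT assay, with a stated time of 48 h; a lower number here means a stronger inhibitor, a higher number a weaker inhibitor:

compound 1 `COc1ccc(-n2c(S)nnc2-c2cc(OC)c(OC)c(OC)c2)cc1`: > 60000 nM (a limit)
compound 2 `CCSc1nnc(-c2cc(OC)c(OC)c(OC)c2)n1-c1ccc(OC)cc1`: 57700 nM
compound 3 `COc1ccc(-n2c(SCC(=O)c3ccc4ccccc4c3)nnc2-c2cc(OC)c(OC)c(OC)c2)cc1`: > 60000 nM (a limit)

Compound 3 gives > 60000 nM, which is a limit and not a number. It stands with compound 1 at the end of the measurable range (the limit of > 60000 nM in this assay, at which 2 of the 3 values shown sit). Within the data shown here, compound 2 is the only compound with a number, 57700 nM, and no measured compound shows clear inhibition.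

Compound 4 `COc1ccc(-n2c(SCC(=O)C3CC3)nnc2-c2cc(OC)c(OC)c(OC)c2)cc1` is the next entry, with cyclopropyl in place of naphthalen-2-yl on a carbonyl carbon. Among the measured compounds shown here, two measured steps bear on this change: an at least 1.0-fold higher number from compound 2 to compound 3 (0.01 log units; that floor lies within the scatter), which alters the same side chain, and an at least 1.0-fold lower number from compound 1 to compound 2 (0.01 log units; that floor lies within the scatter), which alters the substituent on the same sulfur. Both are only floors within the scatter, so neither gives a size or direction for the new change.

In this assay the expected result is an at least 1.2-fold lower number from compound 3 to compound 4 (0.07 log units; that floor lies within the scatter), with no shift beyond the scatter in either direction. The estimated value for compound 4 is 50000 nM, with an expected range from 20000 nM to 60000 nM, and a further limit is quite possible.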

Compound 4, half-maximal inhibitory concentration: 37200 nM
Compound 4: middle estimate off by 1.3-fold (0.13 log units), on the high side; the range from low to high includes it.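

In this assay compound 3 gives > 60000 nM, which is a limit. Cyclopropyl in place of naphthalen-2-yl on a carbonyl carbon gives a number, but the step is only a floor, an at least 1.6-fold lower number from compound 3 to compound 4 (0.20 log units; that floor lies within the scatter), because the starting value sits at the end of the measurable range: the limit of > 60000 nM in this assay, at which 2 of the 4 values shown sit. The other two steps, a 1.6-fold lower number from compound 2 to compound 4 (0.19 log units; within the scatter) and an at least 1.6-fold lower number from compound 1 to compound 4 (0.20 log units; that floor lies within the scatter), also stay within the scatter, so a substituent on the sulfur has still produced no shift of clear size and no compound shown here shows clear inhibition.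

On these data alone, how far the naphthalen-2-yl and cyclopropyl groups truly lie apart remains open while one side of the pair is a limit. Also open, as far as these compounds go, is whether an amine or a carboxylic acid in place of cyclopropyl on the carbonyl carbon would move the value beyond the scatter.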